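Swapping the naphthalene ring for a thiophene ring

The compounds below may be only part of what the source reports. "The series", "measured", "known", "first", "only" and "open" are said of these compounds alone.

Compound 1 `Brc1cn2ccnc2c(-c2ccc3ncn(C4CCCCC4)c3c2)n1`: 19.8%
Compound 2 `c1ccc(-c2cn3ccnc3c(-c3ccc4ncn(C5CCCCC5)c4c3)n2)cc1`: 65.7%
Compound 3 `c1ccc2c(-c3cn4ccnc4c(-c4ccc5ncn(C6CCCCC6)c5c4)n3)cccc2c1`: 16.7%

Three compounds share one core and differ only in the group carried on an aromatic carbon. In a functional assay on UACC-62 cells (Homo sapiens) for inhibition, read by sulforhodamine B assay, with a stated time of 48 h, tested at 10 uM (a lower number here means less inhibition, a higher number more inhibition at the concentration tested (going by the name of the read-out)), compound 3, which carries naphthalen-1-yl, gives the lowest of the three numbers, though compound 1 with bromo lies within the scatter of it, and only compound 2 with phenyl stands clearly higher.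

Compound 4 `c1cn2cc(-c3ccsc3)nc(-c3ccc4ncn(C5CCCCC5)c4c3)c2n1` is the next member. It differs from compound 3 in one place: thiophen-3-yl in place of naphthalen-1-yl on an aromatic carbon.

Among the compounds with values here, two measured steps bear on this. Going from bromo to phenyl gave a number 45.9 percentage points higher from compound 1 to compound 2 (beyond the scatter), while going from phenyl to naphthalen-1-yl gave a number 49 percentage points lower from compound 2 to compound 3 (beyond the scatter). A single six-membered ring of carbon gave a higher number, whereas two fused six-membered rings gave a lower one, level with bromo, as seen in a number 3.1 percentage points lower from compound 1 to compound 3 (within the scatter). Thiophen-3-yl is a single five-membered aromatic ring, so the step from compound 3 to compound 4 is expected to go upward in this assay, by an estimated a number 28.3 percentage points higher from compound 3 to compound 4 (beyond the scatter), though not necessarily as far as phenyl reached. Compound 4 is therefore expected to give about 45%, within a range of 15% to 75%.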

Compound 4, a percentage reported as inhibition, at one concentration (the size of the read-out at that concentration, not a potency): 18.4%
Estimate against measurement, compound 4: 26.6 percentage points above; the measured number falls inside the stated range.
By their numbers in this assay, from the lowest: compounds 3, 4 and 1 (each within the scatter of the next); then compound 2.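

Thiophen-3-yl does not behave like phenyl at this position: in this assay, exchanging one single aromatic ring for the other gives a number 47.3 percentage points lower from compound 2 to compound 4 (beyond the scatter) in a large step. The earlier compounds shown here left room for the idea that any single aromatic ring would give a high number, but the new compound sits level with both the two-ring naphthalen-1-yl group, at a number 1.7 percentage points higher from compound 3 to compound 4 (within the scatter), and the lone bromo atom, at a number 1.4 percentage points lower from compound 1 to compound 4 (within the scatter). Among these four compounds, then, neither having a single ring nor the size of the group tracks the read-out, and only the phenyl of compound 2 stands apart, though no measurement here accounts for that.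

The compounds shown leave open how narrow this preference for phenyl is, and whether a pyridine ring, or a phenyl ring carrying a methoxy group or a fluorine, would stay near compound 2 or fall back to the level of the others. On these data alone, it also remains open what a non-aromatic group at this position, such as an amine or a short alkyl chain, would give.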